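Isopropyl to sec-butyl: working notes on the series

This account rests on a few compounds, and the source may have more. Where it says the series, first, only, none or still open, it means among the compounds named here.

In a functional assay on K562 cells (Homo sapiens) (a lower number here means a stronger inhibitor, a higher number a weaker inhibitor), compound 1 `CCCNC(=O)Nc1ccc(C(C)C)cc1` reads 54000 nM as its value and compound 2 `CCNC(=O)Nc1ccc(C(C)CC)cc1` reads 101000 nM as its value, so these two numbers lie within the scatter of each other and compound 1 has no clear place apart from compound 2.

Compound 3 `CCCNC(=O)Nc1ccc(C(C)CC)cc1` comes from compound 1 through the change methyl in place of hydrogen on a saturated chain carbon, two bonds along the chain from an aromatic carbon with methyl in place of hydrogen on a saturated chain carbon, two bonds along the chain from an aromatic carbon, which turns isopropyl to sec-butyl.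

Among the measured compounds shown here, no measured pair shows this change alone. Compound 2 at 101000 nM already carries sec-butyl and stays within the scatter of compound 1, so no step beyond the scatter is expected in this assay in either direction. The expected step of a 1.0-fold higher number from compound 1 to compound 3 (0.01 log units; within the scatter) is an estimate only. Compound 3 is estimated at 55000 nM with 25000 nM to 110000 nM as the expected range.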

Compound 3, half-maximal inhibitory concentration: 106000 nM
Estimate against measurement, compound 3: 1.9-fold (0.28 log units) below; measured number inside the range.
By their numbers in this assay, from the lowest: compounds 1, 2 and 3 (each within the scatter of the next).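

In this assay, isopropyl to sec-butyl can now be read directly, and methyl in place of hydrogen on a saturated chain carbon, two bonds along the chain from an aromatic carbon, gives a 2.0-fold higher number from compound 1 to compound 3 (0.29 log units; within the scatter) as its step. The same methyl on a saturated chain carbon, two bonds along the chain from an amide-type nitrogen, gives a 1.0-fold higher number from compound 2 to compound 3 (0.02 log units; within the scatter) as its step, so neither single change separates its pair beyond the scatter. Nothing at hand bears on what lies behind these numbers.

Still open, as far as these compounds go, is whether a larger group at the sec-butyl place, such as tert-butyl or a longer chain, would give a step beyond the scatter. The same question stands for an amine or a carboxylic acid on that chain.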